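A few compounds are considered here, and "the series" means these few. Any claim that something is new, unique, unknown or untested is made for them only; others in the source may bear on it.

Measured so far:
compound 1 `C=C1C[C@]23C[C@@]1(O)CC[C@H]2c1ccc(OS(=O)(=O)c2ccc(C)cc2)c(C)c1[C@@H]3Cn1cc(-c2ccc(Br)cc2)nn1` — > 20000 nM
compound 2 `C=C1C[C@]23C[C@@]1(O)CC[C@@H]2c1cccc(C)c1[C@@H]3Cn1cc(-c2ccc(OC)cc2)nn1` — > 20000 nM

In a functional assay on SW480 cells (Homo sapiens) for cytotoxicity, read by MTT assay, with a stated time of 4 days (on this read-out lower numbers stand for stronger inhibition and higher numbers for weaker inhibition), compound 1 gives > 20000 nM, which is a limit of the assay and not a number. Compound 2 gives > 20000 nM, again a limit rather than a number. For the measured compounds named here, compound 1 therefore cannot be placed on a scale: both values shown sit at the same limit, as recorded by the limit of > 20000 nM in this assay, at which 2 of the 2 values shown sit, so no step between measured compounds can be counted and no order can be read between compound 1 and compound 2.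

Compound 3 `C=C1C[C@]23C[C@@]1(O)CC[C@H]2c1ccc(OS(=O)(=O)c2ccc(C)cc2)c(C)c1[C@@H]3Cn1cc(-c2ccc(C(F)(F)F)cc2)nn1` has not yet been measured. It departs from compound 1 by trifluoromethyl in place of bromo on an aromatic carbon. The measured values offer no step size to lean on, only limits. The expected step is a number no higher from compound 1 to compound 3 (the limit leaves the size open), none beyond the scatter, with compound 3 most likely staying at the limit. Compound 3 is expected to give 20000 nM in this assay, with a range of 8000 nM to 50000 nM.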

Compound 3, half-maximal inhibitory concentration: > 20000 nM
Compound 3 was reported as a limit; the forecaster's own chance of this, stated with the estimate: 75%; the middle value sits exactly at the limit.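

In this assay compound 3 gives > 20000 nM, a limit of the assay and not a number. No step can be read from compound 1 to compound 3, since neither value is a number: the limit of > 20000 nM in this assay, at which 3 of the 3 values shown sit.

The compounds shown leave open whether any change to this series yields a measurable value in this assay.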